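A Methyl Removed from the Anilino Ring of Compound 3

The source may report more compounds than this note shows. Statements on the series, on what has been measured and on what is new or still open speak of the compounds shown alone.

Of the compounds shown here, three sharing a core have been measured in a functional assay on MCF7 cells (Homo sapiens) for inhibition, read by CCK-8 assay, with a stated time of 48 h (on this read-out lower numbers stand for stronger inhibition of growth and higher numbers for weaker inhibition of growth), and a fourth awaits measurement. Compound 1 `Cc1ccccc1Nc1nc(Nc2ccccc2)ncc1Cl` and compound 2 `Cc1ccc(Nc2ncc(Cl)c(Nc3ccccc3C)n2)cc1` differ only by hydrogen in place of methyl on an aromatic carbon. In this assay compound 1 gives > 100000 nM, which is a limit of the assay and not a number. Compound 2 in this assay gives > 100000 nM, again a limit. The step that the two limits leave unreadable from compound 2 to compound 1 therefore cannot be read, because both values sit at the limit of > 100000 nM in this assay, at which 2 of the 3 values shown sit.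

Compound 3 `Cc1ccccc1Nc1nc(Nc2ccc(N3CCN(C)CC3)cn2)ncc1Cl` carries a different second ring; the difference between its core and that of compound 2 is not broken down here. In this assay, going by the values given here, compound 3 gives 5210 nM, the only number among the three measured compounds.

Compound 4 `CN1CCN(c2ccc(Nc3ncc(Cl)c(Nc4ccccc4)n3)nc2)CC1` is compound 3 with hydrogen in place of methyl on an aromatic carbon. This is the same kind of change as that from compound 2 to compound 1, but not the same: there the hydrogen entered para to a large group, here it enters ortho to a large group.

The earlier step gives no readable size, so the expectation rests on compound 3 alone and on the small size of the change. In this assay the expected step is a 1.2-fold higher number from compound 3 to compound 4 (0.10 log units; within the scatter). Compound 4 is estimated at 6500 nM, with a range expected to run from 2000 nM to 25000 nM.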

Compound 4, concentration for 50% growth inhibition: 51800 nM
Estimate against measurement, compound 4: 8.0-fold (0.90 log units) below, and the stated range ends below it.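

In this assay, hydrogen in place of methyl on an aromatic carbon, ortho to a large group, gives a 9.9-fold higher number from compound 3 to compound 4 (1.00 log units; beyond the scatter), a step beyond the scatter. On the core of compound 3, then, the difference between the 2-methylphenyl and the phenyl group is readable, and this one pair shows that the loss of a single methyl can change the number by a clear margin. It does not show that the step carries from one core to another: the same kind of change from compound 2 to compound 1 lies at a different place in the molecule, and it cannot be read because both values sit at a limit of the assay, not at a number: the limit of > 100000 nM in this assay, at which 2 of the 4 values shown sit.

The compounds shown leave open whether a fluorine, a chlorine, an ethyl or a methoxy group in place of that methyl would stay close to compound 3 or move as far as hydrogen does. They also leave open how the same change reads on any further core, since one readable pair cannot establish a trend across the series.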